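A Smaller Aryl on the Sulfonyl Sulfur of Compound 2

A few compounds are considered here, and "the series" means these few. Any claim that something is new, unique, unknown or untested is made for them only; others in the source may bear on it.

Compound 1 `O=C(NCc1ccc(CNS(=O)(=O)c2ccc(Cl)cc2)cc1)c1cccnc1`, compound 2 `O=C(NCc1ccc(CNS(=O)(=O)c2cccc3ccccc23)cc1)c1cccnc1` and compound 3 `Cc1ccccc1C(=O)NCc1ccc(CNS(=O)(=O)c2cccc3ccccc23)cc1` were tested in an assay on MDA-MB-231 cells for displacement of a labelled ligand from C-X-C chemokine receptor type 4 (Homo sapiens), read by fluorescence and microscopy, with stated times of 10 min and 30 min; on this read-out higher numbers stand for an effect only at larger amounts of compound and lower numbers for an effect already at smaller amounts. Compound 1 gives 1000 nM, compound 2 gives 1000 nM and compound 3 gives 100 nM. Compound 2 therefore stands level with compound 1, the two together the highest numbers of the three, while compound 3 sits a clear step lower. The step of no change at the digits printed from compound 1 to compound 2 (within the scatter) shows that exchanging the group on the sulfonyl sulfur left the number unchanged, whereas a 10-fold lower number from compound 2 to compound 3 (1.00 log units; beyond the scatter) came from a change at the carbonyl carbon. Compound 4 `Cc1cccc(S(=O)(=O)NCc2ccc(CNC(=O)c3cccnc3)cc2)c1` differs from compound 2 only at the sulfonyl sulfur: 3-methylphenyl in place of naphthalen-1-yl on a sulfonyl sulfur. Only the first of those measured steps bears on this change, and it was flat. For compound 4 the expected step is therefore no change at the digits printed from compound 2 to compound 4 (within the scatter), within the scatter. Compound 4 is estimated at 1000 nM, between 300 nM and 3000 nM.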

Compound 4, effective concentration (reported as EC, without a stated level of effect): 10 nM
Compound 4: the middle estimate sits 100-fold (2.00 log units) above what was measured; measured number outside the range, below it.
By their numbers in this assay, from the lowest: compound 4; then compound 3; then compounds 1 and 2 (each within the scatter of the next).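

In this assay the group on the sulfonyl sulfur turns out to matter a great deal, with a 100-fold lower number from compound 2 to compound 4 (2.00 log units; beyond the scatter) and a 100-fold lower number from compound 1 to compound 4 (2.00 log units; beyond the scatter). The flat step between the two earlier aryl groups therefore did not mean that this position tolerates any aryl group, and the single ring alone does not explain the result, since 4-chlorophenyl also has one. Nothing measured here accounts for the size of these steps.

As far as these compounds go, it remains open whether a methoxy or an amine in place of the methyl would hold this low number. From the compounds shown here alone, it is also open whether 3-methylphenyl on the sulfonyl sulfur and 2-methylphenyl on the carbonyl carbon would work together.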